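Amide to acid on a shared core: expected cytotoxicity

The compounds below may be only part of what the source reports. "The series", "measured", "known", "first", "only" and "open" are said of these compounds alone.

Measured so far:
Compound 1, `Cc1cn([C@@H]2O[C@H](CO[Si](C)(C)C(C)(C)C)[C@@]3(OS(=O)(=O)C=C3NCC(N)=O)[C@H]2O[Si](C)(C)C(C)(C)C)c(=O)n(C)c1=O`: 16000 nM
Compound 2, `CC(=O)NC1=CS(=O)(=O)O[C@@]12[C@@H](CO[Si](C)(C)C(C)(C)C)O[C@@H](n1cc(C)c(=O)n(C)c1=O)[C@@H]2O[Si](C)(C)C(C)(C)C`: >= 80000 nM

In a functional assay on HEL cells (Homo sapiens) for cytotoxicity, read by microscopy (on this read-out higher numbers stand for lower toxicity in this test and lower numbers for higher toxicity in this test), compound 1 gives 16000 nM. Among the compounds with values here, compound 1 holds the only true number seen here; the other value is a limit. In this assay compound 2 reaches only a limit, >= 80000 nM, so no number is known for it. Within the data shown here, the one measured step, an at least 5.0-fold higher number from compound 1 to compound 2 (0.69 log units; beyond the scatter), changes the same carbamoylmethyl group that compound 3 also alters, and it ends at the limit of >= 80000 nM in this assay, at which 1 of the 2 values shown sits.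

Compound 3, `Cc1cn([C@@H]2O[C@H](CO[Si](C)(C)C(C)(C)C)[C@@]3(OS(=O)(=O)C=C3NCC(=O)C(=O)O)[C@H]2O[Si](C)(C)C(C)(C)C)c(=O)n(C)c1=O`, differs from compound 1 by carboxy in place of amino on a carbonyl carbon. Among the measured compounds shown here, only the step from compound 1 to compound 2 bears on this change, and it was at least modest toward a higher number. A similar direction is therefore expected: compound 3 is estimated at 40000 nM, within 12000 nM to 100000 nM, a step of a 2.5-fold higher number from compound 1 to compound 3 (0.40 log units; beyond the scatter), with a fair chance that only a limit is reported.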

Compound 3, minimum cytotoxic concentration: 400000 nM
Compound 3: middle estimate off by 10-fold (1.00 log units), on the low side, and the stated range ends below it.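

In this assay, replacing the amino group on the carbonyl carbon with carboxy gives a 25-fold higher number from compound 1 to compound 3 (1.40 log units; beyond the scatter), and a higher number here means lower toxicity in this test. The earlier step swapped the whole carbamoylmethyl group for acetyl, whereas this one keeps the chain on the amine nitrogen and shows that altering its far end alone is enough for a large step. The step from compound 2 to compound 3 cannot be read, because compound 2 gives only a limit: the limit of >= 80000 nM in this assay, at which 1 of the 3 values shown sits.

The change from carbamoyl to carboxycarbonyl brings in a carboxylic acid and an extra carbonyl together, so the compounds shown cannot say which of the two matters. A carboxymethyl group on the amine nitrogen, or a methyl ester in place of the carboxy, would help separate them.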